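The source may hold more compounds than are shown below. What is called first, only, known or untested is meant among the compounds shown, and "the series" means these compounds.

In an ADME assay on Vero cells (Chlorocebus sabaeus) for cytotoxicity, with a stated time of 72 h (a lower number here means a stronger inhibitor, a higher number a weaker inhibitor), the measured compounds stand as follows.
Compound 1 `COc1cc(-c2ccc(OC(F)(F)F)cc2)ccc1CO[C@@H]1COc2nc([N+](=O)[O-])cn2C1` gives > 128000 nM, a limit of the assay.
Compound 2 `O=[N+]([O-])c1cn2c(n1)OCC(COc1ccc(OC(F)(F)F)cc1)C2` gives > 128000 nM, a limit of the assay.
Compound 3 `O=[N+]([O-])c1cn2c(n1)OCC(COc1ccc(-c3ccc(OC(F)(F)F)cc3)cc1)C2` gives > 128000 nM, a limit of the assay.

Compound 3 thus sits where every shown value sits: the limit of > 128000 nM in this assay, at which 3 of the 3 values shown sit. No number is known for it, only that it lies beyond the top of the measured range, and the same holds for compound 1 and compound 2. Within the data shown here, nothing separates the three, and no compound can be called weaker or stronger than another.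

Compound 4 `O=[N+]([O-])c1cn2c(n1)OCC(COc1ccc(-c3ccc(C(F)(F)F)cc3)cc1)C2` has not yet been measured. It is reached from compound 3 by one change, (trifluoromethyl in place of trifluoromethoxy on an aromatic carbon).

Between measured compounds there is no step to draw on, so the size of this change in this assay must be guessed from the limits alone. Since compound 3 gives > 128000 nM and the other two compounds end at the same limit, the expectation is no step beyond the scatter, with the step from compound 3 to compound 4 estimated as a number no higher from compound 3 to compound 4 (the limit leaves the size open).

The estimate for compound 4 in this assay is therefore 128000 nM, expected to lie between 64000 nM and 300000 nM, and most likely reported again only as a limit.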

Compound 4, half-maximal inhibitory concentration: > 128000 nM
Compound 4 ended at the assay's limit; the forecaster's own chance of this, stated with the estimate: 85%; the middle value lies on the limit itself.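

In this assay compound 4 gives > 128000 nM, a limit of the assay. Neither the step from compound 3 to compound 4 nor the step from compound 2 to compound 4 can be read. The compounds shown leave open whether trifluoromethyl in place of trifluoromethoxy changes anything, and how the four compare: the limit of > 128000 nM in this assay, at which 4 of the 4 values shown sit.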